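The compounds below may be only part of what the source reports. "The series", "measured", "known", "first", "only" and "open" are said of these compounds alone.

Compound 1, `COc1ccc2c(c1)[n+]([O-])nc(NCOC(C)c1ccccc1)[n+]2[O-]`: > 100000 nM in a functional assay on PC-3 cells (Homo sapiens) for cytotoxicity, read by MTT assay, with a stated time of 72 h; a lower number here means a stronger inhibitor, a higher number a weaker inhibitor
Compound 2, `O=[N+]([O-])c1cccc(COCNc2n[n+]([O-])c3ccccc3[n+]2[O-])c1`: > 100000 nM
Compound 3, `COCNc1n[n+]([O-])c2ccccc2[n+]1[O-]`: 4270 nM

Three compounds sharing one core were tested in this assay. The value for compound 1 is a limit of the assay, not a number. The value for compound 2 is likewise a limit. Going by the values given here, compound 3 is thus the only member of the set with a measured number; the other two sit at the limit of > 100000 nM in this assay, at which 2 of the 3 values shown sit, so no step between measured compounds can be drawn and nothing can be said about the size of any difference among them.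

Compound 4, `[O-][n+]1nc(NCOCc2ccccc2)[n+]([O-])c2ccccc21`, has not yet been measured. It differs from compound 3 in one place: phenyl in place of hydrogen on a saturated chain carbon bound to an oxygen on a saturated carbon. Cut one bond further out, the same change reads methyl to benzyl. Among the compounds with values here, no measured step reports what such a change does here. With compound 3 giving 4270 nM, and compound 1 and compound 2 yielding no measured number, a move toward weaker inhibition is expected for compound 4, though its size is uncertain. Compound 4 is estimated at 25000 nM, within 5000 nM to 120000 nM, a step of a 5.9-fold higher number from compound 3 to compound 4 (0.77 log units; beyond the scatter) expected to lie beyond the scatter.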

Compound 4, half-maximal inhibitory concentration: 11900 nM
Compound 4: the middle estimate sits 2.1-fold (0.32 log units) above what was measured; the range from low to high includes it.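

In this assay, going by these compounds alone, the first measured step at this place, on a saturated chain carbon bound to an oxygen on a saturated carbon, is a 2.8-fold higher number from compound 3 to compound 4 (0.45 log units; beyond the scatter): the methyl to benzyl change moves toward weaker inhibition, yet compound 4 still gives a measured number rather than a limit. The second step shows that a change on the aromatic carbon also matters, since hydrogen in place of nitro there gives an at least 8.4-fold lower number from compound 2 to compound 4 (0.92 log units; beyond the scatter). The value of compound 2, > 100000 nM, is a limit of the assay and not a number, so this step gives a bound and not a size, and that limit is shared within the set: the limit of > 100000 nM in this assay, at which 2 of the 4 values shown sit.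

The compounds shown leave open how a longer chain, such as ethyl or propyl, would compare with methyl and benzyl at this place, and how an amine or a carboxylic acid would compare with hydrogen and nitro on the aromatic carbon. They also do not show whether the step from methyl to benzyl keeps its direction and size when a methoxy group sits on the shared core.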